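Swapping the Amide Aryl Group for a Chlorothiophene

The source may hold more compounds than are shown below. What is called first, only, known or untested is meant among the compounds shown, and "the series" means these compounds.

Measured so far:
Compound 1, `O=C(Nc1ccc(Oc2cc(C(F)(F)F)cc(C(F)(F)F)c2)cc1)c1ccc(O)cc1F`: > 50000 nM
Compound 2, `Nc1ccc(C(=O)Nc2ccc(Oc3cc(C(F)(F)F)cc(C(F)(F)F)c3)cc2)c(F)c1`: > 50000 nM

Of the compounds shown here, two sharing a diaryl ether core have been tested in an assay on HEK293 cells for inhibition of Toll-like receptor 8 (Homo sapiens), with a stated time of 16 h; on this read-out lower numbers stand for stronger inhibition and higher numbers for weaker inhibition. Compound 1 gives > 50000 nM in this assay, and that value is a limit of the assay rather than a number. Compound 2 likewise gives > 50000 nM in this assay, again a limit and not a number. Going by the values given here, the only measured step, a step that the two limits leave unreadable from compound 1 to compound 2, is therefore unreadable, since both of its ends sit at the limit of > 50000 nM in this assay, at which 2 of the 2 values shown sit. Compound 2 thus stands at the limit, with no readable value of its own.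

Compound 3, `O=C(Nc1ccc(Oc2cc(C(F)(F)F)cc(C(F)(F)F)c2)cc1)c1sccc1Cl`, changes the amide side: 3-chlorothiophen-2-yl in place of 4-amino-2-fluorophenyl on a carbonyl carbon. Among the compounds with values here, no measured step touches this part of the molecule, and the one step that exists gives no size. The expectation for compound 3 therefore rests only on the fact that both neighbours sit at the limit: the estimated step of an at least 1.2-fold lower number from compound 2 to compound 3 (0.09 log units; that floor lies within the scatter) is expected to stay within scatter of no change. Compound 3 is estimated at 40000 nM in this assay, within a range from 8000 nM to 100000 nM.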

Compound 3, half-maximal inhibitory concentration: 3200 nM
The estimate for compound 3 lay 13-fold (1.10 log units) above the measured number; measured number outside the range, below it.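

In this assay, the group on the carbonyl carbon proves able to shift the result. Putting 3-chlorothiophen-2-yl in place of 4-amino-2-fluorophenyl gives an at least 15-fold lower number from compound 2 to compound 3 (1.19 log units; beyond the scatter), and putting it in place of 2-fluoro-4-hydroxyphenyl gives an at least 15-fold lower number from compound 1 to compound 3 (1.19 log units; beyond the scatter), so the shared core can give a readable number once this group changes, which the earlier pair could not show. Both steps are only minimum sizes, and the true gaps could be larger, because each starts from a limit rather than a number: the limit of > 50000 nM in this assay, at which 2 of the 3 values shown sit.

This single change swaps the six-membered carbon ring for a five-membered ring containing sulfur, adds a chlorine and removes the earlier ring's fluorine and its amino or hydroxy group, so the compounds shown cannot say which of these differences matters. As far as these compounds go, an unsubstituted thiophen-2-yl group, or a thiophene carrying a methyl group in place of the chlorine, would help separate the part played by the ring from that of the chlorine, while the two trifluoromethyl groups stay the same in all three compounds and their role remains open.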